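Extending the chain from compound 2 to compound 3

The source may report more compounds than this note shows. Statements on the series, on what has been measured and on what is new or still open speak of the compounds shown alone.

Compound 1 `CCCCCCCCn1c(=O)[nH]c(=O)c2[nH]c(O)nc21`: 28000 nM
Compound 2 `CCCCCCCCCCn1c(=O)[nH]c(=O)c2[nH]c(O)nc21`: 3700 nM

For the measured compounds named here, in a functional assay (mitochondria, heart) with Bos taurus as the target (on this read-out higher numbers stand for weaker inhibition and lower numbers for stronger inhibition), compound 2 stands at 3700 nM, the lower of the two numbers so far and therefore the stronger inhibition. The next compound is compound 3 `CCCCCCCCCCCCn1c(=O)[nH]c(=O)c2[nH]c(O)nc21`. Its structure differs from that of compound 2 at one place: ethyl in place of hydrogen on a saturated chain carbon, ten or more bonds along the chain from an aromatic nitrogen. Going by the values given here, only one measured step bears on this change. It is the same swap of hydrogen for ethyl, made eight bonds along the chain, and it gave a 7.6-fold lower number from compound 1 to compound 2 (0.88 log units; beyond the scatter), a modest step beyond the scatter. A single step cannot show whether the trend continues, but it points to a further drop of similar or somewhat smaller size in this assay. The expected change is a 4.1-fold lower number from compound 2 to compound 3 (0.61 log units; beyond the scatter). For compound 3 the estimate is 900 nM, with an expected range from 250 nM to 3500 nM.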

Compound 3, half-maximal inhibitory concentration in the Bos taurus assay: 1600 nM
Compound 3: middle estimate off by 1.8-fold (0.25 log units), on the low side; measured number inside the range.
By their numbers in the Bos taurus assay, from the lowest: compound 3; then compound 2; then compound 1.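

Ethyl in place of hydrogen on this saturated chain carbon still strengthens inhibition in the Bos taurus assay, with a 2.3-fold lower number from compound 2 to compound 3 (0.36 log units; beyond the scatter), but this gain is smaller than the earlier one, a 7.6-fold lower number from compound 1 to compound 2 (0.88 log units; beyond the scatter). Across all three compounds in the Bos taurus assay, each lengthening lowers the number and none goes against this, adding up to an 18-fold lower number from compound 1 to compound 3 (1.24 log units; beyond the scatter). In a physicochemical assay for lipophilicity (on this read-out higher numbers stand for higher lipophilicity and lower numbers for lower lipophilicity), compound 2 gives 2.04 and compound 3 gives 2.9. Lipophilicity rises along with inhibition at this step, which makes it a possible reason for the gain, though it does not prove it: the measured partition coefficient of compound 2, 2.04, and of compound 3, 2.9, a number 0.86 log units higher (beyond the scatter).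

Going by these compounds, whether a longer chain would lower the number further, level off or reverse the trend remains open. Also open, on these data alone, is how a chain carrying a carboxylic acid or an amine would behave, which would help show whether chain length alone matters.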